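The compounds below may be only part of what the source reports. "The series", "measured", "known", "first", "only" and "open" are said of these compounds alone.

Compound 1 `Cn1cc(-c2cnc3c(-c4csc(C(=O)N[C@@H]5CCCC[C@H]5O)c4)cnn3c2)cn1` stands weakest of the two measured compounds in an assay for inhibition of MAP/microtubule affinity-regulating kinase 3 (Homo sapiens), read by HTRF, with a stated time of 2 h; on this read-out lower numbers stand for stronger inhibition and higher numbers for weaker inhibition: compound 1 gives 24 nM, whereas compound 2 `Cc1sc(C(=O)N[C@@H]2CCCC[C@@H]2N)cc1-c1cnn2cc(-c3cnn(C)c3)cnc12` gives 1.3 nM, a gap beyond the scatter. Compound 3 `CCNC(=O)c1cc(-c2cnn3cc(-c4cnn(C)c4)cnc23)cs1` is derived from compound 1 by ethyl in place of 2-hydroxycyclohexyl on an amide-type nitrogen. Among the compounds with values here, no measured pair shows this change, so no step for it can be read from the numbers at hand. The expected step of a 2.5-fold higher number from compound 1 to compound 3 (0.40 log units; beyond the scatter) is a modest weakening, probably a little beyond the scatter. Compound 3 is therefore estimated at 60 nM, with a range from 20 nM to 200 nM.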

Compound 3, half-maximal inhibitory concentration: 129 nM
For compound 3 the middle estimate is 2.2-fold (0.33 log units) below the measured one; measured number inside the range.
By their numbers in this assay, from the lowest: compound 2; then compound 1; then compound 3.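

On the amide-type nitrogen, ethyl in place of 2-hydroxycyclohexyl gives a 5.4-fold higher number from compound 1 to compound 3 (0.73 log units; beyond the scatter) in this assay. This substituent therefore bears on the read-out, yet the loss is partial, as compound 3 still gives 129 nM with the ring and the hydroxyl gone. No measurement at hand gives a reason for the step. The compounds shown leave open whether the ring or the hydroxyl accounts for the step. An unsubstituted cyclohexyl or a longer chain such as butyl on the same nitrogen would separate the two.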